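Naphthalenyl for tert-butylphenyl on a theophylline ester

This account rests on a few compounds, and the source may have more. Where it says the series, first, only, none or still open, it means among the compounds named here.

Compound 1 `COC(C(=O)OC(C)Cn1cnc2c1c(=O)n(C)c(=O)n2C)c1ccc(C(C)(C)C)cc1`: 0%
Compound 2 `CC(Cn1cnc2c1c(=O)n(C)c(=O)n2C)OC(=O)Sc1ccccc1`: 0.5%
Compound 3 `CC(Cn1cnc2c1c(=O)n(C)c(=O)n2C)OCc1cn(CCCn2cnc3c(Br)c(Br)c(Br)c(Br)c32)nn1`: 0%

Of the compounds shown here, three that share a core have been tested in a functional assay on CCRF-CEM cells (Homo sapiens) for antiproliferative activity, read by MTT assay, with a stated time of 72 h, tested at 200 uM; on this read-out higher numbers stand for a weaker effect at the one concentration tested and lower numbers for a stronger effect. Compound 1 gives 0%, and compound 3 gives the same reading at the digits reported, so the two stand level. Compound 2 gives 0.5%, a reading that lies within the scatter of compound 1 as well. Going by the values given here, none of the three shows an effect beyond the scatter in this assay, and no pair of them differs in only one place, so no step can be drawn from the measured set.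

Compound 4 `COC(C(=O)OC(C)Cn1cnc2c1c(=O)n(C)c(=O)n2C)c1cccc2ccccc12` has not yet been measured. It differs from compound 1 in one place: naphthalen-1-yl in place of 4-(tert-butyl)phenyl on a saturated chain carbon bound to a carbonyl carbon and an oxygen on a saturated carbon. Since the three measured compounds, which differ widely in what sits on the same side of the core, all read alike, the step from compound 1 to compound 4 is expected to stay within the scatter, with no direction to it; the expected step is a number 1 percentage points higher from compound 1 to compound 4 (within the scatter). Compound 4 is therefore expected to give about 1% in this assay, somewhere between 0% and 10%.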

Compound 4, a percentage reported as activity, at one concentration (the size of the read-out at that concentration, not a potency): 34.6%
Beside the measured number, compound 4's estimate is 33.6 percentage points below it; the measured number lies above the stated range.
By their numbers in this assay, from the lowest: compounds 1, 3 and 2 (each within the scatter of the next); then compound 4.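

On a saturated chain carbon bound to a carbonyl carbon and an oxygen on a saturated carbon, naphthalen-1-yl in place of 4-(tert-butyl)phenyl gives, in this assay, a number 34.6 percentage points higher from compound 1 to compound 4 (beyond the scatter) and so a weaker effect at the one concentration tested. This first readable step shows that the reading responds to the group at this position, even though both groups have the same heavy-atom count, all carbon, and the entering group carries 2 six-membered aromatic rings of carbon only where the leaving group carries one. Nothing measured here accounts for the change.

The compounds shown do not separate the effect of the second ring from the absence of the tert-butyl group, a question that a plain phenyl or a naphthalen-2-yl on the same carbon would address. They also leave open whether the step holds when the ester is replaced by an amide.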